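Working notes: side-chain swap from compound 2 to compound 3

A few compounds are considered here, and "the series" means these few. Any claim that something is new, unique, unknown or untested is made for them only; others in the source may bear on it.

Measured so far in a functional assay on DU-145 cells (Homo sapiens) for cytotoxicity, read by MTT assay; a higher number here means a weaker inhibitor, a lower number a stronger inhibitor:
- compound 1 `CCC(CO[C@H](CC=C(C)C)C1=CC(=O)c2c(O)ccc(O)c2C1=O)OC(C)=O`: 25400 nM
- compound 2 `CCCCC(C)(O)CC(=O)O[C@H](CC=C(C)C)C1=CC(=O)c2c(O)ccc(O)c2C1=O`: 76500 nM

Compound 2, at 76500 nM, holds the higher of the two numbers and is the weaker of the pair. The next analogue is compound 3 `CCC(CO[C@H](CC=C(C)C)C1=CC(=O)c2c(O)ccc(O)c2C1=O)OC`, described by 2-methoxybutyl in place of (2-hydroxy-2-methylhexyl)carbonyl on an oxygen on a saturated carbon. In words, this is 2-methoxybutyl in place of (2-hydroxy-2-methylhexyl)carbonyl on an oxygen on a saturated carbon. Among the measured compounds shown here, one measured step bears on this change: a 3.0-fold higher number from compound 1 to compound 2 (0.48 log units; beyond the scatter). That modest step, beyond the scatter, brought in the same (2-hydroxy-2-methylhexyl)carbonyl in place of 2-acetoxybutyl. The group entering now is a butyl group, like the 2-acetoxybutyl of compound 1 at 25400 nM, so a modest step of similar size towards a lower number is expected in this assay. For the measured compounds named here, no measured compound carries 2-methoxybutyl, so the range stays wide. The expected step is a 2.6-fold lower number from compound 2 to compound 3 (0.41 log units; beyond the scatter). Compound 3 is estimated at 30000 nM, with an expected range of 12000 nM to 70000 nM.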

Compound 3, half-maximal inhibitory concentration: 45700 nM
For compound 3 the middle estimate is 1.5-fold (0.18 log units) below the measured one; measured number inside the range.
By their numbers in this assay, from the lowest: compounds 1, 3 and 2 (each within the scatter of the next, the first and the last beyond it).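

In this assay the replacement of the (2-hydroxy-2-methylhexyl)carbonyl by 2-methoxybutyl gives a 1.7-fold lower number from compound 2 to compound 3 (0.22 log units; within the scatter) and the exchange of acetyl for methyl on the butyl side chain gives a 1.8-fold higher number from compound 1 to compound 3 (0.26 log units; within the scatter) so compound 3 cannot be ranked against either compound 1 or compound 2. The second step adds what the earlier pair could not show: with the butyl chain held constant, exchanging acetyl for methyl on that oxygen leaves a difference no larger than the scatter, so this assay does not show that the acetyl is needed for the number of compound 1. Compound 3 also lacks the hydrogen-bond donor of the (2-hydroxy-2-methylhexyl)carbonyl group, yet its number cannot be told apart from that of compound 2, and no measurement at hand explains any of these numbers.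

The compounds shown leave open whether a free hydroxyl, an amine or a carboxylic acid on the butyl chain would move the number beyond the scatter. They also leave open whether a longer chain in place of the methyl or acetyl would do so, in either direction.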